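From 4-Chlorophenyl to 3-Methylphenyl on a Shared Core

This account rests on a few compounds, and the source may have more. Where it says the series, first, only, none or still open, it means among the compounds named here.

In a functional assay on OVCAR-3 cells (Homo sapiens) for inhibition, read by MTT assay, with a stated time of 24 h (a higher number here means a weaker inhibitor, a lower number a stronger inhibitor), three compounds with a shared core have measured numbers. Compound 1 (`CC1(C)[C@H]2CC[C@]1(C)N(Cc1cn(-c3ccccc3F)nn1)C(=O)C2`) gives 300 nM, compound 2 (`CC1(C)[C@H]2CC[C@]1(C)N(Cc1cn(-c3cccc(Cl)c3)nn1)C(=O)C2`) gives 50 nM, and compound 3 (`CC1(C)[C@H]2CC[C@]1(C)N(Cc1cn(-c3ccc(Cl)cc3)nn1)C(=O)C2`) gives 160 nM. Among these numbers, compound 3 has one close neighbour and one distant one: a 1.9-fold lower number from compound 1 to compound 3 (0.27 log units; within the scatter), and a 3.2-fold higher number from compound 2 to compound 3 (0.51 log units; beyond the scatter).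

Compound 4 (`Cc1cccc(-n2cc(CN3C(=O)C[C@@H]4CC[C@@]3(C)C4(C)C)nn2)c1`) has 3-methylphenyl in place of 4-chlorophenyl on an aromatic nitrogen. Among the measured compounds shown here, no measured step exchanges chlorine for methyl, so the closest guide is the step between the two chlorophenyl isomers, a 3.2-fold higher number from compound 2 to compound 3 (0.51 log units; beyond the scatter). The group in compound 4 bears the same number as the 3-chlorophenyl of compound 2, but the data do not show whether methyl can stand in for chlorine, so only part of that step is expected to return. The step expected for compound 4 is small and toward a lower number: a 1.8-fold lower number from compound 3 to compound 4 (0.25 log units; within the scatter). Compound 4 is estimated at 90 nM, with an expected range of 30 nM to 270 nM.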

Compound 4, half-maximal inhibitory concentration: 160 nM
For compound 4 the middle estimate is 1.8-fold (0.25 log units) below the measured one; the measured number falls inside the stated range.
By their numbers in this assay, from the lowest: compound 2; then compounds 3, 4 and 1 (each within the scatter of the next).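

In this assay, replacing the chloro of compound 2 with methyl gives a 3.2-fold higher number from compound 2 to compound 4 (0.51 log units; beyond the scatter) and so shows that methyl does not stand in for chloro here; the 3-methylphenyl group does not bring the low value of the 3-chlorophenyl group. Compound 4 cannot be told apart from its other two neighbours, with no change at the digits printed from compound 3 to compound 4 (within the scatter) and a 1.9-fold lower number from compound 1 to compound 4 (0.27 log units; within the scatter), so among these four compounds only the 3-chlorophenyl of compound 2 stands apart. Nothing available explains why chloro and methyl differ in this assay.

The compounds shown leave open whether bromo, trifluoromethyl or methoxy in place of that chloro would hold the number of compound 2 at 50 nM or would join compound 4. They also leave open what an amine or a carboxylic acid on the phenyl ring would do.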